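Methyl for methoxy on the aryl ring

The source may report more compounds than this note shows. Statements on the series, on what has been measured and on what is new or still open speak of the compounds shown alone.

Measured so far in a functional assay on HeLa cells (Homo sapiens) for inhibition, read by sulforhodamine B assay, with a stated time of 48 h; a lower number here means a stronger inhibitor of growth, a higher number a weaker inhibitor of growth:
compound 1, `O=C(/C=C/c1ccc(Cl)cc1)N1CCC=CS1(=O)=O`, 26400 nM
compound 2, `COc1ccc(/C=C/C(=O)N2CCC=CS2(=O)=O)cc1`, 24400 nM

Compound 2 holds the lowest of the two numbers, yet the gap between the two is a 1.1-fold lower number from compound 1 to compound 2 (0.03 log units; within the scatter), within the scatter. Compound 3 is `Cc1ccc(/C=C/C(=O)N2CCC=CS2(=O)=O)cc1`; the change from compound 2 is methyl in place of methoxy on an aromatic carbon. Within the data shown here, the only step that bears on it is a 1.1-fold lower number from compound 1 to compound 2 (0.03 log units; within the scatter), a swap of one small group for another that moved nothing beyond the scatter. A similar outcome is therefore expected here: compound 3 is estimated at 25000 nM (range 12000 nM to 52000 nM), a step of a 1.0-fold higher number from compound 2 to compound 3 (0.01 log units; within the scatter).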

Compound 3, concentration for 50% growth inhibition: 18600 nM
Beside the measured number, compound 3's estimate is 1.3-fold (0.13 log units) above it, and the stated range covers the measured number.
By their numbers in this assay, from the lowest: compounds 3, 2 and 1 (each within the scatter of the next).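

In this assay, methyl on this aromatic carbon, para to a large group, stays within the scatter of both methoxy (a 1.3-fold lower number from compound 2 to compound 3 (0.12 log units; within the scatter)) and chloro (a 1.4-fold lower number from compound 1 to compound 3 (0.15 log units; within the scatter)). Removing the oxygen and its hydrogen-bond acceptor therefore gives no readable change, and the three groups cannot be told apart here. No measurement bears on why these groups read alike.

Going by these compounds, whether an amine or a carboxylic acid at this position would move the number beyond the scatter remains open. So does the effect of a longer chain in place of methyl.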